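The source may hold more compounds than are shown below. What is called first, only, known or untested is meant among the compounds shown, and "the series" means these compounds.

Compound 1 `Nc1ccccc1Nc1n[n+]([O-])c2ccccc2[n+]1[O-]`: in a functional assay on PC-3 cells (Homo sapiens) for cytotoxicity, read by MTT assay, with a stated time of 48 h (on this read-out lower numbers stand for stronger inhibition and higher numbers for weaker inhibition), compound 1 gives 16100 nM.
Compound 2 `COc1ccc(Nc2n[n+]([O-])c3ccccc3[n+]2[O-])cc1`: compound 2 gives 12000 nM.
Compound 3 `[O-][n+]1nc(Nc2ccccc2)[n+]([O-])c2ccccc21`: compound 3 gives 17000 nM.

Compound 3 holds the highest of these three numbers, yet its gap to each other compound stays within the scatter: a 1.1-fold higher number from compound 1 to compound 3 (0.02 log units; within the scatter) and a 1.4-fold higher number from compound 2 to compound 3 (0.15 log units; within the scatter). Compound 4 `Cc1ccc(Nc2n[n+]([O-])c3ccccc3[n+]2[O-])cc1` is compound 3 with methyl in place of hydrogen on an aromatic carbon. Both measured steps bear on this change, as each also exchanges a small group for hydrogen on an aromatic carbon, and neither moved the number beyond the scatter. Putting a methyl in place of hydrogen is therefore expected to leave the number essentially where it is, with no step beyond the scatter, a 1.1-fold lower number from compound 3 to compound 4 (0.05 log units; within the scatter). Compound 4 is estimated at 15000 nM, between 7000 nM and 32000 nM.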

Compound 4, half-maximal inhibitory concentration: 10300 nM
Estimate against measurement, compound 4: 1.5-fold (0.16 log units) above; measured number inside the range.
By their numbers in this assay, from the lowest: compounds 4, 2, 1 and 3 (each within the scatter of the next).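

In this assay, methyl in place of hydrogen on the aromatic carbon para to a large group gives a 1.7-fold lower number from compound 3 to compound 4 (0.22 log units; within the scatter), which stays within the scatter. Methyl in place of methoxy at that same carbon gives a 1.2-fold lower number from compound 2 to compound 4 (0.07 log units; within the scatter), so hydrogen, methoxy and methyl cannot be told apart there on this read-out. No measured evidence bears on these small steps.

Going by these compounds, whether a carboxylic acid, an amine or a longer chain at this carbon would move the number beyond the scatter stays open. So does the effect of methyl on other carbons of this ring.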